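The compounds below may be only part of what the source reports. "The series", "measured", "known", "first", "only" and "open" are said of these compounds alone.

Three compounds share a core and differ only in the aromatic group attached to the five-membered ring of that core. Compound 1 `COc1cc(-c2cccc3nc(-c4ccccc4)oc23)cc(OC)c1OC` carries a phenyl there, and in a functional assay on A549 cells (Homo sapiens) for antiproliferative activity, read by MTT assay, with a stated time of 48 h (a higher number here means a weaker inhibitor, a lower number a stronger inhibitor), compound 1 gives 20300 nM. Compound 2 `COc1ccc(-c2nc3cccc(-c4cc(OC)c(OC)c(OC)c4)c3o2)cc1` adds a methoxy to that phenyl; in this assay compound 2 gives 2200 nM, so that a 9.2-fold lower number from compound 1 to compound 2 (0.97 log units; beyond the scatter). Compound 3 `COc1ccc(-c2nc3cccc(-c4cc(OC)c(OC)c(OC)c4)c3o2)cc1F` further adds a fluoro; in this assay compound 3 gives 1800 nM, with a 1.2-fold lower number from compound 2 to compound 3 (0.09 log units; within the scatter) and, overall, an 11-fold lower number from compound 1 to compound 3 (1.05 log units; beyond the scatter). Compound 3 thus stands at the low end of the three numbers, beyond the scatter from compound 1 but within it from compound 2.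

Compound 4 `COc1cc(-c2cccc3nc(-c4cccc(Cl)c4)oc23)cc(OC)c1OC` makes the change (3-chlorophenyl in place of 3-fluoro-4-methoxyphenyl on an aromatic carbon). The methoxy whose arrival brought the step of a 9.2-fold lower number from compound 1 to compound 2 (0.97 log units; beyond the scatter) is lost, while the fluoro whose arrival brought only a 1.2-fold lower number from compound 2 to compound 3 (0.09 log units; within the scatter) is replaced by a chlorine. The number for compound 4 is therefore expected to move back toward that of compound 1, by a 5.6-fold higher number from compound 3 to compound 4 (0.74 log units; beyond the scatter). Compound 4 is estimated at 10000 nM, with a range from 3000 nM to 30000 nM.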

Compound 4, half-maximal inhibitory concentration: > 25000 nM
Compound 4: only a limit was reported; the forecaster's own chance of this, stated with the estimate: 10%; middle value at least 2.5-fold (0.39 log units) away from the limit.
By their numbers in this assay, from the lowest: compounds 3 and 2 (each within the scatter of the next); then compound 1. At a limit, above all of these: compound 4.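

In this assay compound 4 is known only as a limit: the limit of > 25000 nM in this assay, at which 1 of the 4 values shown sits. Replacing the substituted aryl groups at this position, on the carbon next to the ring nitrogen and next to the ring oxygen, with 3-chlorophenyl gives an at least 13-fold higher number from compound 3 to compound 4 (1.14 log units; beyond the scatter) and an at least 11-fold higher number from compound 2 to compound 4 (1.05 log units; beyond the scatter), so the chlorine does not stand in for the gain seen with the methoxy-bearing groups. Against the plain phenyl the step is an at least 1.2-fold higher number from compound 1 to compound 4 (0.09 log units; that floor lies within the scatter), which means chloro shows none of the drop that methoxy brought, although the true size of this step cannot be read from a limit.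

The compounds shown leave open whether a chloro kept together with the methoxy would hold the lower numbers. They also leave open whether an amine, a hydroxyl or a longer ether chain such as ethoxy could take the place of the methoxy.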